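A few compounds are considered here, and "the series" means these few. Any claim that something is new, unique, unknown or untested is made for them only; others in the source may bear on it.

Compounds measured so far:
- compound 1 `CC(C)(C)C1=NN(c2ccc(Br)cc2)C(c2ccc(O)cc2)C1`: 11400 nM
- compound 2 `CC(C)(C)C1=NN(c2ccc(C(F)(F)F)cc2)C(c2ccc(O)cc2)C1`: 8800 nM
- compound 3 `CC(C)(C)C1=NN(c2ccc(C(=O)O)cc2)C(c2ccc(O)cc2)C1`: "not determined" (no result reported) (no result was reported)

All three share one core and differ only in the group on the phenyl ring attached to the ring nitrogen. In an assay on isolated protein for inhibition of protein kinase C zeta type (Homo sapiens), with a stated time of 4 min (a higher number here means a weaker inhibitor, a lower number a stronger inhibitor), compound 1 gives 11400 nM, the highest of the two numbers available; its nearest neighbour is compound 2, and the step of a 1.3-fold lower number from compound 1 to compound 2 (0.11 log units; within the scatter) lies within the scatter. Compound 3 has no number, so it cannot be placed.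

Compound 4 `CC(C)(C)C1=NN(c2cccc(F)c2)C(c2ccc(O)cc2)C1` is the next compound. Its difference from compound 1 is 3-fluorophenyl in place of 4-bromophenyl on an amine nitrogen in a ring. For the measured compounds named here, the only measured step that touches the same ring is the one from compound 1 to compound 2, a 1.3-fold lower number from compound 1 to compound 2 (0.11 log units; within the scatter), and it stayed within the scatter. Going by the values given here, that step swapped one group for another at the same spot; no measured step moves the halogen to a different spot on that ring or replaces bromo with fluoro, so the data give no direct guide. Among the compounds with values here, with the one related step showing no change beyond the scatter, no step beyond the scatter is expected here either.

For compound 4 in this assay the estimate is 12000 nM, with a range from 5000 nM to 30000 nM. The estimated step from compound 1 to compound 4 is a 1.1-fold higher number from compound 1 to compound 4 (0.02 log units; within the scatter).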

Compound 4, half-maximal inhibitory concentration: 2200 nM
Beside the measured number, compound 4's estimate is 5.5-fold (0.74 log units) above it; the whole stated range lies above it.
By their numbers in this assay, from the lowest: compound 4; then compounds 2 and 1 (each within the scatter of the next).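

In this assay, 3-fluorophenyl in place of 4-bromophenyl gives a 5.2-fold lower number from compound 1 to compound 4 (0.71 log units; beyond the scatter), so the group on this ring nitrogen can move the number by more than the scatter, a modest but real change. The earlier swap at this ring, a 1.3-fold lower number from compound 1 to compound 2 (0.11 log units; within the scatter), had not shown this, since it stayed within the scatter and left open whether the position responded at all. This new change alters two things at once, the halogen and its place on the ring, and the compounds shown cannot separate these two, while no measurement here explains the lower number.

Fluoro and bromo each appear at only one spot on this ring, so it remains open whether the halogen or its place matters more, and compound 3, with its carboxylic acid, gives no number to help. Also open, on these data alone, is how a nitrile or an amine on this ring would behave, and whether a longer chain in place of the tert-butyl group or a change to the 4-hydroxyphenyl group would shift the number as much.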